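The source may hold more compounds than are shown below. What is called first, only, known or untested is meant among the compounds shown, and "the series" means these compounds.

Compound 1 `O=C1NC(c2ccccc2)CN1S(=O)(=O)c1ccc2c(c1)CCCN2` — in a functional assay on A549 cells (Homo sapiens) for antiproliferative activity, read by MTT assay (on this read-out higher numbers stand for weaker inhibition and lower numbers for stronger inhibition), compound 1 gives > 20000 nM, which is a limit of the assay rather than a number.
Compound 2 `CC(C)COC(=O)N1CCCc2cc(S(=O)(=O)N3CC(c4ccccc4)NC3=O)ccc21` — in this assay compound 2 gives > 20000 nM, again a limit.
Compound 3 `O=C1NC(c2ccccc2)CN1S(=O)(=O)c1ccc2c(c1)CCCN2C(=O)C(F)(F)F` — in this assay compound 3 gives > 20000 nM, also a limit.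

Compound 1 therefore stands at the limit of this assay, as do the two other compounds shown; the step from compound 1 to compound 2 is a step that the two limits leave unreadable from compound 1 to compound 2, that from compound 1 to compound 3 is a step that the two limits leave unreadable from compound 1 to compound 3, and that from compound 2 to compound 3 is a step that the two limits leave unreadable from compound 2 to compound 3. All three values sit at the limit of > 20000 nM in this assay, at which 3 of the 3 values shown sit.

Compound 4 `O=C(NC1CCCCC1)N1CCCc2cc(S(=O)(=O)N3CC(c4ccccc4)NC3=O)ccc21` differs from compound 1 by cyclohexylcarbamoyl in place of hydrogen on a nitrogen on an aromatic ring in a ring. The steps from compound 1 to compound 2 and to compound 3 are the ones that bear on it, since each also puts a carbonyl-bearing group on that same nitrogen, and neither gave a readable size. No expectation of a step beyond the scatter in this assay can be drawn from them in either direction, so compound 4 is expected to remain at the limit as well. The estimate for compound 4 in this assay is 30000 nM, with a range from 8000 nM to 120000 nM, which as a step from compound 1 is expected to be a step that the limit leaves unreadable from compound 1 to compound 4.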

Compound 4, half-maximal inhibitory concentration: 231 nM
For compound 4 the middle estimate is 130-fold (2.11 log units) above the measured one, outside the stated range (below it).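

In this assay, the nitrogen on an aromatic ring in a ring now gives a readable result: cyclohexylcarbamoyl in place of hydrogen brings an at least 86-fold lower number from compound 1 to compound 4 (1.93 log units; beyond the scatter). A carbonyl on this nitrogen is therefore not enough by itself, and what stands on the carbonyl carbon matters, as cyclohexylamino in place of trifluoromethyl brings an at least 86-fold lower number from compound 3 to compound 4 (1.93 log units; beyond the scatter), and cyclohexylamino in place of isobutoxy brings an at least 86-fold lower number from compound 2 to compound 4 (1.93 log units; beyond the scatter). The steps among compound 1, compound 2 and compound 3 cannot be read, and the new steps are sized only against a limit: the limit of > 20000 nM in this assay, at which 3 of the 4 values shown sit.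

Within the data shown here, compound 4 is the only compound here with a readable value, so how far the cyclohexyl ring and the amide hydrogen each contribute stays open. As far as these compounds go, whether phenylcarbamoyl, methylcarbamoyl or cyclohexylcarbonyl on the same nitrogen would give a similar value also remains unknown.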